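This account rests on a few compounds, and the source may have more. Where it says the series, first, only, none or still open, it means among the compounds named here.

Compounds measured in a functional assay on the whole organism with Rattus norvegicus as the target, at a dose of 1 mg/kg by the oral route; on this read-out lower numbers stand for a weaker effect and higher numbers for a stronger effect at the one dose given:
compound 1, `COc1cc(C(=O)Nc2nn[nH]n2)nc(-c2ccccc2)c1`: 62%
compound 2, `COc1cc(C(=O)Nc2nn[nH]n2)nc(-c2ccc(C)cc2)c1`: 42%

Compound 2 has the lower of the two numbers. Its nearest neighbour is compound 1, which stands higher by the step of a number 20 percentage points lower from compound 1 to compound 2 (beyond the scatter), a difference beyond the usual scatter.

Compound 3, `Cc1ccc(-c2cccc(C(=O)Nc3nn[nH]n3)n2)cc1`, has not yet been measured in this assay. It differs from compound 2 by a single change: hydrogen in place of methoxy on an aromatic carbon. The change is a loss of the methoxy group at that aromatic carbon, with nothing but a hydrogen atom taking its place.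

For the measured compounds named here, no measured step bears directly on this change. Going by the values given here, the one step available, a number 20 percentage points lower from compound 1 to compound 2 (beyond the scatter), concerns a methyl group entering on a different ring and says nothing about what the methoxy group contributes. Among the compounds with values here, with no step to lean on, the expectation for the loss of the methoxy group is a step of no clear direction, most likely within the scatter, although a modest move in either direction cannot be excluded. The expected step from compound 2 is therefore a number 4 percentage points lower from compound 2 to compound 3 (within the scatter). For compound 3 in this assay the estimate is 38%, with a likely range from 15% to 60%.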

Compound 3, a percentage reported as inhibition, in the whole organism at one dose (the size of the read-out at that dose, not a potency): 67%
For compound 3 the middle estimate is 29 percentage points below the measured one; the whole stated range lies below it.
By their numbers in this assay, from the lowest: compound 2; then compounds 1 and 3 (each within the scatter of the next).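

The step of a number 25 percentage points higher from compound 2 to compound 3 (beyond the scatter) in this assay shows that, with the 4-methylphenyl group in place, the methoxy group opposite the ring nitrogen is not needed for the effect at the one dose given, and that the hydrogen there goes with the higher number. Compound 1 and compound 2 both carry this methoxy group, so their values could say nothing about this position, whereas this pair isolates it and gives a change beyond the scatter. Nothing at hand gives a measured reason for the size or direction of this step.

As far as these compounds go, what remains open is whether the loss of the methoxy group would read the same on the core of compound 1, which has no methyl group, since this single pair shows the change only with the 4-methylphenyl group present. From the compounds shown here alone, it also remains open how an amine, a hydroxyl group or an ethoxy group on this same aromatic carbon would read in this assay when set against the hydrogen of compound 3.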